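The source may hold more compounds than are shown below. What is called first, only, known or untested is meant among the compounds shown, and "the series" means these compounds.

In a functional assay on A16-F10 cells (Homo sapiens) for antiproliferative activity, read by MTT assay, with a stated time of 48 h (on this read-out lower numbers stand for stronger inhibition and higher numbers for weaker inhibition), three compounds sharing the core are measured: compound 1 `Oc1ccccc1CNc1ccc2ncnc(Nc3cccc(Br)c3)c2c1` gives 1870 nM, compound 2 `Clc1ccc(CNc2ccc3ncnc(Nc4cccc(Br)c4)c3c2)cc1` gives 1820 nM and compound 3 `Brc1ccc(CNc2ccc3ncnc(Nc4cccc(Br)c4)c3c2)cc1` gives 2210 nM. Compound 2 therefore stands level with both neighbours, all within the scatter.

Compound 4 `Brc1cccc(Nc2ncnc3ccc(NCc4ccccc4Br)cc23)c1` is the next to be read, with this change from compound 2: 2-bromophenyl in place of 4-chlorophenyl on a saturated chain carbon bound to a nitrogen on an aromatic ring. The same difference reads as 4-chlorobenzyl to 2-bromobenzyl.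

Within the data shown here, three measured steps bear on it. Bromo in place of chloro on an aromatic carbon gave a 1.2-fold higher number from compound 2 to compound 3 (0.08 log units; within the scatter). 4-Chlorophenyl in place of 2-hydroxyphenyl gave a 1.0-fold lower number from compound 1 to compound 2 (0.01 log units; within the scatter), and 4-bromophenyl in place of 2-hydroxyphenyl gave a 1.2-fold higher number from compound 1 to compound 3 (0.07 log units; within the scatter). Among the measured compounds shown here, none of these leaves the scatter, although no 2-bromophenyl compound has been measured, so this evidence is indirect.

No shift beyond the scatter is expected in this assay, and the expected step is a 1.1-fold higher number from compound 2 to compound 4 (0.04 log units; within the scatter). Compound 4 is estimated at 2000 nM, with an expected range of 1000 nM to 4000 nM.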

Compound 4, half-maximal inhibitory concentration: 4380 nM
Compound 4: the middle estimate sits 2.2-fold (0.34 log units) below what was measured; the whole stated range lies below it.
By their numbers in this assay, from the lowest: compounds 2, 1, 3 and 4 (each within the scatter of the next, the first and the last beyond it).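

In this assay, among these compounds, 2-bromophenyl is the only group of the four at this place, on a saturated chain carbon bound to a nitrogen on an aromatic ring, with steps beyond the scatter: a 2.4-fold higher number from compound 2 to compound 4 (0.38 log units; beyond the scatter) and a 2.3-fold higher number from compound 1 to compound 4 (0.37 log units; beyond the scatter), both modest, whereas the three earlier groups stayed level with one another. The pattern is not complete, since 2-bromophenyl in place of 4-bromophenyl gives a 2.0-fold higher number from compound 3 to compound 4 (0.30 log units; within the scatter) and stays within the scatter. No measurement shown speaks to the reason for these steps.

Open, on these data alone, is whether the result belongs to bromo itself or would recur with chloro, methoxy, an amine or a carboxylic acid on the same ring carbon. Also open, as far as these compounds go, is how a longer chain in place of the single saturated carbon would read in this assay.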